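Notes on the step from compound 3 to compound 4

The source may report more compounds than this note shows. Statements on the series, on what has been measured and on what is new or still open speak of the compounds shown alone.

Measured so far in a functional assay on MCF7 cells (Homo sapiens) for antiproliferative activity, read by MTT assay, with a stated time of 72 h; on this read-out higher numbers stand for weaker inhibition and lower numbers for stronger inhibition:
- compound 1 `O=C(Nc1ccc(Nc2nccc(NC3CCCC3)n2)cc1)Nc1ccc(Cl)c(C(F)(F)F)c1` at 2330 nM
- compound 2 `O=C(Nc1ccc(Nc2nccc(Nc3ccc(Cl)cc3)n2)cc1)Nc1ccc(Cl)c(C(F)(F)F)c1` at 12800 nM
- compound 3 `O=C(Nc1ccc(Nc2nccc(NC3CCCC3)n2)cc1)Nc1cccc(C(F)(F)F)c1` at 5180 nM

Compound 3 holds the second highest of the three numbers, between compound 1 and compound 2. In compound 4 `O=C(CC1CCCCC1)Nc1ccc(Nc2nccc(NC3CCCC3)n2)cc1` the change is cyclohexylmethyl in place of (3-(trifluoromethyl)phenyl)amino on a carbonyl carbon and so cyclohexylmethyl stands in place of (3-(trifluoromethyl)phenyl)amino on a carbonyl carbon. The nearest evidence is a 2.2-fold higher number from compound 1 to compound 3 (0.35 log units; beyond the scatter) for hydrogen in place of chloro on the aromatic ring that now leaves. The other measured step, a 5.5-fold higher number from compound 1 to compound 2 (0.74 log units; beyond the scatter), concerns cyclopentyl, which compound 4 keeps. Within the data shown here, no measured compound lacks that aromatic ring, so a modest step to a higher number in this assay is expected only tentatively. The expected step is a 1.7-fold higher number from compound 3 to compound 4 (0.24 log units; within the scatter) by this estimate. For compound 4 the estimate is 9000 nM, with an expected range from 3500 nM to 25000 nM.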

Compound 4, half-maximal inhibitory concentration: 17600 nM
Compound 4: the middle estimate sits 2.0-fold (0.29 log units) below what was measured; the measured number falls inside the stated range.
By their numbers in this assay, from the lowest: compound 1; then compound 3; then compounds 2 and 4 (each within the scatter of the next).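

In this assay, among these compounds, the earlier steps changed only the chloro on the aromatic ring or the cyclopentyl group, whereas this change replaces the whole (3-(trifluoromethyl)phenyl)amino group on the carbonyl carbon. Cyclohexylmethyl there gives a 3.4-fold higher number from compound 3 to compound 4 (0.53 log units; beyond the scatter), so inhibition weakens modestly but a measurable number remains. No evidence given here accounts for the rise. As far as these compounds go, the aromatic ring and the amino nitrogen leave together, so their separate contributions remain open. Cyclohexylamino or benzyl on the carbonyl carbon would separate them.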